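A few compounds are considered here, and "the series" means these few. Any claim that something is new, unique, unknown or untested is made for them only; others in the source may bear on it.

Compound 1 (`C=C1C(=O)O[C@]2(C)CC[C@@H]1C[C@H](O)[C@@]1(C)CC[C@H](O1)[C@](C)(O)CC[C@H]2O`) and compound 2 (`C=C1C(=O)O[C@]2(C)CC[C@@H]1C[C@H](O)[C@@]1(C)CC[C@H](O1)[C@](C)(O)CCC2=O`) share the same core and were both measured in a functional assay on HEp-2 cells (Homo sapiens) for cytotoxicity; a higher number here means a weaker inhibitor, a lower number a stronger inhibitor. Compound 1 gives > 20 ug/mL as a limit of the assay, not a number. Compound 2 gives > 20 ug/mL as a limit of the assay, not a number. So compound 2 has no exact value yet, only a place alongside compound 1 (the limit of > 20 ug/mL in this assay, at which 2 of the 2 values shown sit). Compound 3 (`C=C1C(=O)O[C@]2(C)CC[C@@H]1C[C@H](OC(C)=O)[C@@]1(C)CC[C@H](O1)[C@](C)(O)CCC2=O`) is compound 2 with a single change (acetyl in place of hydrogen on an oxygen on a saturated carbon): an acetyl in place of hydrogen on an oxygen on a saturated carbon, or hydroxy to acetoxy. Among the measured compounds shown here, no measured pair shows what this change does in this assay, so the expected step (a number no higher from compound 2 to compound 3 (the limit leaves the size open)) is none beyond the scatter, in either direction. For compound 3 the estimated value is 20 ug/mL with an expected range from 8 ug/mL to 40 ug/mL and a good chance of another limit.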

Compound 3, half-maximal inhibitory concentration: > 20 ug/mL
Compound 3: only a limit was reported (the forecaster's own chance of this, stated with the estimate: 70%); the middle value sits exactly at the limit.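

Compound 2 and compound 3 both stand at a limit of this assay, not at a number, so no step between them can be read: the limit of > 20 ug/mL in this assay, at which 3 of the 3 values shown sit.

The compounds shown leave open what an acetyl in place of hydrogen does to the value in this assay, and how far beyond the limit each compound lies.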